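The source may report more compounds than this note shows. Statements on the series, on what has been measured and on what is new or still open speak of the compounds shown alone.

Compound 2 `CCCCCCCCCCn1cc(-c2nc3ccccc3cc2CCCC)nn1` shows only a limit in a functional assay on THP-1 cells (Homo sapiens) for cytotoxicity, read by MTT assay, with a stated time of 24 h (on this read-out higher numbers stand for weaker inhibition and lower numbers for stronger inhibition), namely > 100 ug/mL. Compound 1 `CCCCCCCCCCn1cc(-c2nc3ccccc3cc2C)nn1` likewise gives a limit, > 100 ug/mL. The step that the two limits leave unreadable from compound 1 to compound 2 is therefore unreadable, and the limit of > 100 ug/mL in this assay, at which 2 of the 2 values shown sit, marks where both values sit. Compound 3 `CCCCCCCCCCn1cc(-c2nc3ccccc3cc2CC)nn1` differs from compound 2 by hydrogen in place of ethyl on a saturated chain carbon, two bonds along the chain from an aromatic carbon. Within the data shown here, no readable step bears on this change, since the one measured step stays hidden by two limits. The expected step is a step that the limit leaves unreadable from compound 2 to compound 3, none beyond the scatter, most likely ending again in a limit. The estimate for compound 3 is 150 ug/mL, between 50 ug/mL and 500 ug/mL.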

Compound 3, half-maximal inhibitory concentration: 34.3 ug/mL
Estimate against measurement, compound 3: 4.4-fold (0.64 log units) above; the whole stated range lies above it.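

In this assay, butyl to ethyl gives an at least 2.9-fold lower number from compound 2 to compound 3 (0.46 log units; beyond the scatter), and methyl in place of hydrogen on the saturated chain carbon bound to an aromatic carbon gives an at least 2.9-fold lower number from compound 1 to compound 3 (0.46 log units; beyond the scatter). Among these compounds, compound 3, with ethyl, thus gives the first readable value at this position, and the number does not run in one direction with chain length. Compound 1 and compound 2 remain at a limit: the limit of > 100 ug/mL in this assay, at which 2 of the 3 values shown sit.

The step from compound 1 to compound 2 cannot be read. As far as these compounds go, whether a propyl chain, or an amine or carboxylic acid at the end of the ethyl chain, would keep the lower number stays open.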